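This account rests on a few compounds, and the source may have more. Where it says the series, first, only, none or still open, it means among the compounds named here.

Measured compounds:
compound 1 `CCOc1ncc(-c2nc(C(F)(F)F)sc2N2CCN(C(=O)Cn3cnc4ccccc43)[C@H](C)C2)cn1`: 2 nM
compound 2 `CCOc1ncc(-c2nc(C(F)(F)F)sc2N2CCN(C(=O)Cn3c(=O)oc4ccccc43)[C@H](C)C2)cn1`: 3.3 nM
compound 3 `CCOc1ncc(-c2nc(C(F)(F)F)sc2N2CCN(C(=O)Cn3nc(C)nc3C)[C@H](C)C2)cn1`: 7 nM

All three were read in a functional assay on CHO-K1 cells for antagonist activity at C-X-C chemokine receptor type 3 (Homo sapiens), read by FLIPR, with a stated time of 10 min; on this read-out lower numbers stand for stronger inhibition and higher numbers for weaker inhibition. Compound 3 gives the highest number of the three: a 3.5-fold higher number from compound 1 to compound 3 (0.54 log units; beyond the scatter) and a 2.1-fold higher number from compound 2 to compound 3 (0.33 log units; beyond the scatter), both beyond the scatter, whereas a 1.7-fold higher number from compound 1 to compound 2 (0.22 log units; within the scatter) stays within it. Within the data shown here, every measured step so far changes the group on the saturated chain carbon bound to the carbonyl carbon; the shared core and the group on the aromatic carbon of the five-membered ring are held constant.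

Compound 4 `COc1ccc(-c2nc(C(F)(F)F)sc2N2CCN(C(=O)Cn3nc(C)nc3C)[C@H](C)C2)cn1` departs from compound 3 in exactly that constant part: 6-methoxypyridin-3-yl in place of 2-ethoxypyrimidin-5-yl on an aromatic carbon. Among the measured compounds shown here, no measured step touches this position, so none of the three steps bears directly on the change; the only information is that compound 3 itself sits at 7 nM. With nothing to point in either direction, the expectation for this assay is a step from compound 3 to compound 4 of about a 1.4-fold higher number from compound 3 to compound 4 (0.15 log units; within the scatter), not beyond the scatter. Compound 4 is therefore estimated at 10 nM, with a range from 3 nM to 35 nM.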

Compound 4, half-maximal inhibitory concentration: 18 nM
For compound 4 the middle estimate is 1.8-fold (0.26 log units) below the measured one; the measured number falls inside the stated range.
By their numbers in this assay, from the lowest: compounds 1 and 2 (each within the scatter of the next); then compound 3; then compound 4.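

In this assay the group on the aromatic carbon of the five-membered ring is shown for the first time to affect the read-out: 6-methoxypyridin-3-yl in place of 2-ethoxypyrimidin-5-yl gives a 2.6-fold higher number from compound 3 to compound 4 (0.41 log units; beyond the scatter) with 3,5-dimethyl-1H-1,2,4-triazol-1-yl held constant. The change removes one ring nitrogen and also replaces ethoxy with methoxy, so this single step cannot separate the two alterations. Nothing available here explains the step. As far as these compounds go, whether 2-methoxypyrimidin-5-yl or 6-ethoxypyridin-3-yl would follow compound 3 or compound 4 remains open, and either would help to separate the ring nitrogen from the chain length. Also open, from the compounds shown here alone, is whether a step of this size recurs when 1H-benzimidazol-1-yl sits on the saturated chain carbon bound to the carbonyl carbon.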